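This account rests on a few compounds, and the source may have more. Where it says the series, first, only, none or still open, it means among the compounds named here.

Measured in a functional assay on NCI-H460 cells (Homo sapiens) for cytotoxicity, read by MTT assay, with a stated time of 72 h; a higher number here means a weaker inhibitor, a lower number a stronger inhibitor:
- compound 1 `CCCCNC1=CC(=O)C(C[C@]2(C)[C@@H](C)CC[C@]3(C)C(C)=CCC[C@@H]23)=CC1=O`: > 100000 nM (a limit)
- compound 2 `CC(C)(C)C1=CC(=O)C=CC1=O`: > 100000 nM (a limit)
- compound 3 `CCNC1=CC(=O)C(C(C)(C)C)=CC1=O`: 64000 nM

Among the compounds with values here, compound 3, at 64000 nM, is the only compound here with an actual number. Compound 1 and compound 2 sit at the limit of > 100000 nM in this assay, at which 2 of the 3 values shown sit, which is a limit of the assay and not a number.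

Compound 4 `CCCCCCCCNC1=CC(=O)C(C(C)(C)C)=CC1=O` keeps the core of compound 3 and extends its ethyl chain: hexyl in place of hydrogen on a saturated chain carbon, two bonds along the chain from an amine nitrogen. Seen one bond further out, this is methyl to heptyl.

Within the data shown here, the only measured step nearby is an at least 1.5-fold lower number from compound 2 to compound 3 (0.19 log units; that floor lies within the scatter). Among the measured compounds shown here, that step installs the ethylamino group, and no measured step lengthens a chain on this core, so it is a weak guide. It points, tentatively, towards a modest move to a lower number in this assay, though a return to the limit remains possible. The expected change is a 2.6-fold lower number from compound 3 to compound 4 (0.41 log units; beyond the scatter). For compound 4 the estimated value is 25000 nM, with an expected range of 6000 nM to 100000 nM.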

Compound 4, half-maximal inhibitory concentration: 70000 nM
For compound 4 the middle estimate is 2.8-fold (0.45 log units) below the measured one; low and high end bracket the measured number.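

In this assay, hexyl in place of hydrogen on a saturated chain carbon, two bonds along the chain from an amine nitrogen, gives a 1.1-fold higher number from compound 3 to compound 4 (0.04 log units; within the scatter). Compound 3 and compound 4 therefore cannot be told apart, which shows that this position tolerates a much longer chain, while the added length offers no measurable benefit. Compound 4 also gives an actual number rather than a limit, so the core now has two measured values, while the remaining compounds stay unranked: the limit of > 100000 nM in this assay, at which 2 of the 4 values shown sit.

Going by these compounds, whether any change at this position can give a clearly lower number in this assay remains open. A chain ending in an amine or a carboxylic acid, or a ring in place of the chain, could behave differently from the plain chains of compound 3 and compound 4.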